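Halogen Pattern on the Benzyl Group and Modulator Potency

This account rests on a few compounds, and the source may have more. Where it says the series, first, only, none or still open, it means among the compounds named here.

Measured compounds:
compound 1, `COc1ccc2[nH]c3c(c2c1)CCNC31CCN(Cc2c(F)ccc(Cl)c2F)CC1`: 1500 nM
compound 2, `COc1ccc2[nH]c3c(c2c1)CCNC31CCN(Cc2ccccc2Cl)CC1`: 2200 nM
compound 3, `COc1ccc2[nH]c3c(c2c1)CCNC31CCN(Cc2ccc(F)c(Cl)c2F)CC1`: 4500 nM

In an assay on FRT cells for positive allosteric modulation of Cystic fibrosis transmembrane conductance regulator variant N1303K (Homo sapiens), in the presence of a further agent that is not named here (on this read-out higher numbers stand for an effect only at larger amounts of compound and lower numbers for an effect already at smaller amounts), compound 1 holds the lowest of the three numbers. Its step to compound 2 is a 1.5-fold higher number from compound 1 to compound 2 (0.17 log units; within the scatter), so these two cannot be separated. Its step to compound 3 is a 3.0-fold higher number from compound 1 to compound 3 (0.48 log units; beyond the scatter), a modest rise. Between the other two, the step is a 2.0-fold higher number from compound 2 to compound 3 (0.31 log units; beyond the scatter).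

Compound 4, `COc1ccc2[nH]c3c(c2c1)CCNC31CCN(Cc2cccc(F)c2F)CC1`, has not yet been measured in this assay. It differs from compound 1 in one place: 2,3-difluorophenyl in place of 3-chloro-2,6-difluorophenyl on a saturated chain carbon bound to an amine nitrogen in a ring. Both measured steps that start from compound 1 change the same group at the same place, and each gives either no change beyond the scatter or a modest rise. A change that leaves the chlorine behind has not been measured, so the nearest guide is the pair of steps to compound 2 and compound 3.

On this basis compound 4 is expected to give 3000 nM in this assay, within a range of 1500 nM to 7000 nM. The expected step is a 2.0-fold higher number from compound 1 to compound 4 (0.30 log units; within the scatter), a modest move toward an effect only at larger amounts of compound.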

Compound 4, half-maximal effective concentration: 13600 nM
The estimate for compound 4 lay 4.5-fold (0.66 log units) below the measured number; the measured number lies above the stated range.
By their numbers in this assay, from the lowest: compounds 1 and 2 (each within the scatter of the next); then compound 3; then compound 4.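

The earlier compounds shown here suggested that this place on a saturated chain carbon bound to an amine nitrogen in a ring tolerated changes in the halogen pattern with only small or modest shifts, but the 2,3-difluorophenyl group moves the number well beyond that in this assay, with a 9.1-fold higher number from compound 1 to compound 4 (0.96 log units; beyond the scatter), a 6.2-fold higher number from compound 2 to compound 4 (0.79 log units; beyond the scatter) and a 3.0-fold higher number from compound 3 to compound 4 (0.48 log units; beyond the scatter). Compound 4, the only one of the four without a chlorine, therefore has a higher number than each chlorine-bearing compound, and none of the four goes against this pattern, while two fluorines alone do not secure a low number. No measurement shown here explains why this change has so large a step.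

Because the fluorines of compound 4 do not carry the same positions as those in compound 1 or compound 3, the loss of chlorine cannot be separated from the change in the fluorine pattern. On these data alone, it also remains open whether a bromine, a methyl group or a trifluoromethyl group in place of the chlorine would give numbers like those of compound 1 and compound 2.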